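This account rests on a few compounds, and the source may have more. Where it says the series, first, only, none or still open, it means among the compounds named here.

Of the compounds shown here, three sharing one core have been tested in a functional assay on HeLa cells (Homo sapiens) for inhibition, read by sulforhodamine B assay, with a stated time of 48 h; on this read-out lower numbers stand for stronger inhibition of growth and higher numbers for weaker inhibition of growth. Compound 1 `COc1cccc(/C=C/C(=O)N2CCC=CS2(=O)=O)c1` gives 23700 nM, compound 2 `Cc1cccc(/C=C/C(=O)N2CCC=CS2(=O)=O)c1` gives 20700 nM, and compound 3 `COc1ccc(/C=C/C(=O)N2CCC=CS2(=O)=O)cc1` gives 24400 nM. Compound 1 and compound 2 differ in one place, (methyl in place of methoxy on an aromatic carbon), and this gave a 1.1-fold lower number from compound 1 to compound 2 (0.06 log units; within the scatter). Compound 3 has the same atoms as compound 1 joined differently; the difference between the two cores is not broken down here.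

Compound 4 `Cc1ccc(/C=C/C(=O)N2CCC=CS2(=O)=O)cc1` has not yet been measured. It differs from compound 3 by methyl in place of methoxy on an aromatic carbon. This is the same kind of change as from compound 1 to compound 2, though in that pair the place is meta to a large group, whereas here it is para to a large group. From compound 3 to compound 4 the step expected in this assay is a 1.1-fold lower number from compound 3 to compound 4 (0.05 log units; within the scatter), beside a 1.1-fold lower number from compound 1 to compound 2 (0.06 log units; within the scatter), because that earlier step a 1.1-fold lower number from compound 1 to compound 2 (0.06 log units; within the scatter) was small. Compound 4 is therefore estimated at 21500 nM, likely between 12000 nM and 40000 nM.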

Compound 4, concentration for 50% growth inhibition: 18600 nM
Compound 4: middle estimate off by 1.2-fold (0.06 log units), on the high side; the range from low to high includes it.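

In this assay, methyl in place of methoxy para to a large group gave a 1.3-fold lower number from compound 3 to compound 4 (0.12 log units; within the scatter). Set beside the earlier case of the same change, the two steps do not differ: the same change on two cores in this assay, a 1.1-fold lower number (0.06 log units; within the scatter) from compound 1 to compound 2 and a 1.3-fold lower number (0.12 log units; within the scatter) from compound 3 to compound 4, 1.1-fold (0.06 log units) apart, within the scatter of two such steps The change therefore carried from one core to the other in these two pairs, but each step is small, so this shows only that the swap moved the number little on both cores, and it does not show that a change with a larger step would carry across in the same way.

The aromatic groups shown are only methoxy and methyl. As far as these compounds go, how an amine or a carboxylic acid at that place would read in this assay stays open, as does whether such a group would behave alike on both cores.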